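A few compounds are considered here, and "the series" means these few. Any claim that something is new, unique, unknown or untested is made for them only; others in the source may bear on it.

Compound 2 `CC(C)=CCC/C(C)=C/CC1Cc2c(OCCCNC(=O)c3cccs3)cc(=O)n(CCCO)c2CC1(C)C` stands at the top of three measured numbers in a functional assay on PANC-1 cells (Homo sapiens) for inhibition, read by MTT assay, with a stated time of 24 h, tested at 10 uM (on this read-out lower numbers stand for less inhibition and higher numbers for more inhibition at the one concentration tested (going by the name of the read-out)), where compound 2 gives 72.8%. Its gap to compound 3 `CC(C)=CCC/C(C)=C/CC1Cc2c(OCCCOc3ccc([N+](=O)[O-])cc3)cc(=O)n(CCCO)c2CC1(C)C`, which in this assay gives 65.1%, lies within the scatter, as a number 7.7 percentage points lower from compound 2 to compound 3 (within the scatter) shows, so the two cannot be ranked; only the gap to compound 1 `COc1ccc(C(=O)NCCCOc2cc(=O)n(CCCO)c3c2CC(C/C=C(\C)CCC=C(C)C)C(C)(C)C3)cc1`, which gives 45.7%, is beyond the scatter, as a number 27.1 percentage points higher from compound 1 to compound 2 (beyond the scatter) shows.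

Compound 4 `CC(C)=CCC/C(C)=C/CC1Cc2c(OC(=O)Nc3ccc(Cl)c(Cl)c3)cc(=O)n(CCCO)c2CC1(C)C` is built from compound 2 by the change ((3,4-dichlorophenyl)carbamoyl in place of 3-(((thiophen-2-yl)carbonyl)amino)propyl on an oxygen on an aromatic ring). Both measured steps bear on this site: from compound 1 to compound 2 the amide substituent was exchanged for a modest gain, and from compound 2 to compound 3 the whole chain end was replaced for a difference within the scatter. Neither step, however, removes the three-carbon chain itself, as the change to compound 4 does, so the measured steps set only a loose guide. She therefore expects a small to modest step, probably downward, from compound 2 to compound 4 in this assay, amounting to a number 12.8 percentage points lower from compound 2 to compound 4 (beyond the scatter). Her estimate for compound 4 in this assay is 60%, expected to fall between 40% and 78%.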

Compound 4, a percentage reported as inhibition, at one concentration (the size of the read-out at that concentration, not a potency): 20%
Compound 4: middle estimate off by 40 percentage points, on the high side; measured number below the stated range.
By their numbers in this assay, from the lowest: compound 4; then compound 1; then compounds 3 and 2 (each within the scatter of the next).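

In this assay the exchange at the oxygen on an aromatic ring gives a number 52.8 percentage points lower from compound 2 to compound 4 (beyond the scatter), a far larger movement than the earlier changes at this site produced, which were a number 27.1 percentage points higher from compound 1 to compound 2 (beyond the scatter) and a number 7.7 percentage points lower from compound 2 to compound 3 (within the scatter). Those earlier compounds all keep the propyl chain and differ only in what it carries, so they made the site look fairly forgiving; compound 4, with (3,4-dichlorophenyl)carbamoyl directly on that oxygen, shows that the read-out can fall sharply when the 3-(((thiophen-2-yl)carbonyl)amino)propyl group goes as a whole. Nothing measured here accounts for this fall.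

The single step replaces the chain, the link and the end ring together, so the compounds shown do not tell which of these parts carries the loss. Also open, from the compounds shown here alone, is how a propyl chain ending in 3,4-dichlorophenyl amide, a carbamoyl bearing thiophene, or a longer chain ending in an amine would read in this assay at this position.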